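A few compounds are considered here, and "the series" means these few. Any claim that something is new, unique, unknown or untested is made for them only; others in the source may bear on it.

Measured compounds:
- compound 1 `CCOC(=O)c1sc(-c2cccc(NC(=O)c3ccc(C(C)(C)C)cc3)c2)nc1Nc1ccc(N2CCN(C)CC2)cc1` — "not determined" (no result reported) in a functional assay on Raji cells (Homo sapiens) for antiproliferative activity, read by CCK-8 assay, with a stated time of 72 h; a lower number here means a stronger inhibitor, a higher number a weaker inhibitor
- compound 2 `CCOC(=O)c1sc(-c2cccc(NC(=O)c3ccccc3)c2)nc1Nc1ccc(N2CCN(C)CC2)cc1` — "not determined" (no result reported) in this assay
- compound 3 `CCOC(=O)c1sc(-c2cccc(NC(=O)c3cccc(F)c3)c2)nc1Nc1ccc(N2CCN(C)CC2)cc1` — 21200 nM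

Compound 1 stands without a number in this assay, and compound 2 is a second entry for which no result was reported. The only figure in this set belongs to compound 3, which carries fluorine on the aryl ring of the amide rather than the tert-butyl group of compound 1; in this assay compound 3 gives 21200 nM, a weak inhibition. For the measured compounds named here, nothing else in this set has a value, so no step between measured compounds can be drawn, and nothing can be said about the tert-butyl analogue compound 1 in comparison.

Compound 4 `CCOC(=O)c1sc(-c2cccc(NC(=O)c3ccccc3F)c2)nc1Nc1ccc(N2CCN(C)CC2)cc1` is not yet measured. It differs from compound 1 by 2-fluorophenyl in place of 4-(tert-butyl)phenyl on a carbonyl carbon. Since compound 1 has no number, the size and direction of this step in this assay cannot be anchored; the closest guide is compound 3, which carries a fluorophenyl amide of its own and is weak. Compound 4 is therefore expected to sit in the same weak region, with an estimated value of 20000 nM and a likely range from 5000 nM to 60000 nM, because compound 3 gives 21200 nM. That expectation rests on a single data point and should be read loosely.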

Compound 4, half-maximal inhibitory concentration: 9270 nM
Beside the measured number, compound 4's estimate is 2.2-fold (0.33 log units) above it; low and high end bracket the measured number.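

In this assay, the set now holds its first readable step: 2-fluorophenyl in place of 3-fluorophenyl on a carbonyl carbon gives a 2.3-fold lower number from compound 3 to compound 4 (0.36 log units; beyond the scatter), a modest change that lies beyond the usual scatter. This shows what compound 3 alone could not, namely that the number at this amide aryl group responds to a change as small as the place of the fluorine on the ring, although compound 4, at 9270 nM, still remains a weak inhibitor. The data shown contain no measurement that would explain this difference.

Steps from compound 1 and compound 2 to the fluorinated compounds cannot be read, since neither of those two has a number, so the effect of fluorine against the plain phenyl of compound 2, or of the 4-(tert-butyl)phenyl of compound 1, stays unknown. Also open, going by these compounds, is whether the change seen for compound 4 extends to other groups at this place, such as 2-chlorophenyl, 2-methoxyphenyl or a phenyl ring carrying a dimethylamino group.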